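Fluoro in place of hydrogen: three measured, one expected

The source may report more compounds than this note shows. Statements on the series, on what has been measured and on what is new or still open speak of the compounds shown alone.

Compound 1, `COC(=O)NC1=NC(c2ccccc2F)CN1`, in a functional assay on the whole organism for antagonist activity, with Mus musculus as the target, in the maximal electroshock model (a higher number here means that more compound is needed for the effect, a lower number that less compound is needed), gives 54 mg/kg.
Compound 2, `COC(=O)NC1=NC(c2cc(F)ccc2F)CN1`, in this assay gives 49 mg/kg.
Compound 3, `CCOC(=O)NC1=NC(c2ccccc2)CN1C`, in this assay gives 78 mg/kg.

Among the measured compounds shown here, the one change seen twice in this set is fluoro in place of hydrogen on an aromatic carbon. From the measured pair it gave a 1.1-fold lower number from compound 1 to compound 2 (0.04 log units; within the scatter). Compound 3 carries a different core from compound 1; the difference between the two cores is not broken down here. The values of compound 3, compound 1 and compound 2 in this assay lie within the scatter of one another, so nothing is read into their ordering.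

Compound 4, `CCOC(=O)NC1=NC(c2ccc(F)cc2)CN1C`, has not been measured. It differs from compound 3 by fluoro in place of hydrogen on an aromatic carbon. This is the same kind of change as that from compound 1 to compound 2, but not the same: in the earlier pair the fluoro enters meta to a large group and para to a fluoro group, whereas in compound 4 it enters para to a large group. With a single measured precedent, and that one within the scatter, the expectation for compound 4 rests on compound 3 giving 78 mg/kg and on the earlier step of a 1.1-fold lower number from compound 1 to compound 2 (0.04 log units; within the scatter). The expected step is a 1.1-fold lower number from compound 3 to compound 4 (0.05 log units; within the scatter). Compound 4 is thus estimated at 70 mg/kg, with a likely range from 35 mg/kg to 140 mg/kg.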

Compound 4, dose for half-maximal effect: 100 mg/kg
Beside the measured number, compound 4's estimate is 1.4-fold (0.15 log units) below it; measured number inside the range.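

In this assay, fluoro in place of hydrogen on an aromatic carbon gave a 1.3-fold higher number from compound 3 to compound 4 (0.11 log units; within the scatter). Set beside the earlier step, the new step does not differ from it: the same change on two cores in this assay, a 1.1-fold lower number (0.04 log units; within the scatter) from compound 1 to compound 2 and a 1.3-fold higher number (0.11 log units; within the scatter) from compound 3 to compound 4, 1.4-fold (0.15 log units) apart, within the scatter of two such steps. On these two cores the change therefore shows no step beyond the scatter and no sign that the core alters its size, but two steps that both lie within the scatter, with fluoro entering para to a large group only in the second pair, do not show that the change carries over unaltered, nor that it would stay this small at other places on the ring or on other cores.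

The compounds shown carry only hydrogen or fluoro on the aromatic ring, so it remains open whether a methoxy group, a trifluoromethyl group, an amine or a carboxylic acid there would move the number beyond the scatter. Also open, from the compounds shown here alone, is whether a longer chain in place of the ethyl group of compound 3 and compound 4 would do so, and whether any such change would read the same on the core of compound 1 and on the core of compound 3.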